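Methoxy for methyl on two tetrazole cores

The compounds below may be only part of what the source reports. "The series", "measured", "known", "first", "only" and "open" are said of these compounds alone.

Measured so far:
compound 1, `Cc1ccc(Cn2nnc(-c3cc([N+](=O)[O-])cc([N+](=O)[O-])c3)n2)cc1`, in an ADME assay on CHO-K1 cells (Cricetulus griseus) for cytotoxicity, read by MTT assay, with a stated time of 24 h (a lower number here means a stronger inhibitor, a higher number a weaker inhibitor), gives 200000 nM
compound 2, `COc1ccc(Cn2nnc(-c3cc([N+](=O)[O-])cc([N+](=O)[O-])c3)n2)cc1`, in this assay gives 96000 nM
compound 3, `Cc1ccc(Cn2nnnc2-c2cc([N+](=O)[O-])cc([N+](=O)[O-])c2)cc1`, in this assay gives 28000 nM

Compounds 1 and 2 share one core and differ only in the change (methoxy in place of methyl on an aromatic carbon). That change brought a 2.1-fold lower number from compound 1 to compound 2 (0.32 log units; beyond the scatter). Compound 3 is built from the same atoms as compound 1, joined differently; the difference between the two cores is not broken down here. Compound 3 gives the lowest of the three numbers, and its distances to compound 2 and to compound 1 both lie beyond the scatter.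

Compound 4, `COc1ccc(Cn2nnnc2-c2cc([N+](=O)[O-])cc([N+](=O)[O-])c2)cc1`, has not yet been measured. It differs from compound 3 by methoxy in place of methyl on an aromatic carbon. Within the data shown here, this is the same change as the one from compound 1 to compound 2: the group that leaves, the group that enters and the place on the ring are the same. It occurs twice among the compounds shown, once measured and once not.

From compound 3 to compound 4 a step of a 2.0-fold lower number from compound 3 to compound 4 (0.30 log units; within the scatter) is expected, because the same change gave a 2.1-fold lower number from compound 1 to compound 2 (0.32 log units; beyond the scatter). That expectation rests on a single measured pair, and the core of compound 3 is not the core on which that step was seen, so the width of the range is set accordingly. Compound 4 is expected to give 14000 nM, with a likely range from 6000 nM to 35000 nM.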

Compound 4, half-maximal inhibitory concentration: 21000 nM
Compound 4: middle estimate off by 1.5-fold (0.18 log units), on the low side, and the stated range covers the measured number.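

On the core of compound 3, the change from methyl to methoxy gives, in this assay, a 1.3-fold lower number from compound 3 to compound 4 (0.12 log units; within the scatter), so on this core the step does not separate the two compounds. Set beside the earlier step, it shows no difference between the two cores in what this change does, and so far as these four compounds can tell, the step carries from one core to the other: the same change on two cores in this assay, a 2.1-fold lower number (0.32 log units; beyond the scatter) from compound 1 to compound 2 and a 1.3-fold lower number (0.12 log units; within the scatter) from compound 3 to compound 4, 1.6-fold (0.19 log units) apart, within the scatter of two such steps Each step rests on a single pair and only one of them lies beyond the scatter, so the comparison does not establish that the two steps are equal, nor does it say how the change would behave on any third core.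

The compounds shown hold only the 4-methylphenyl and 4-methoxyphenyl forms, which leaves open how a chlorine atom, an amine or a carboxylic acid at that place would read on either core. Every compound shown also keeps its nitro groups, and what a nitrile or an amine in their stead would give in this assay remains open as well.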